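The compounds below may be only part of what the source reports. "The series", "measured", "known", "first", "only" and "open" are said of these compounds alone.

Of the compounds shown here, three have been measured in an assay on isolated protein for inhibition of RAC-alpha serine/threonine-protein kinase (Homo sapiens); a lower number here means a stronger inhibitor, a higher number a weaker inhibitor. Compound 1, `CCOCCN(C[C@@H](O)CN1CCC2(CCN(c3ncnc4[nH]nc(C)c34)C2)C1)S(=O)(=O)c1c(C)cccc1C`, gives 17 nM in this assay. Compound 2, `CCOCCN(C[C@@H](O)CN1CCCC2(CCN(c3ncnc4ccccc34)C2)C1)S(=O)(=O)c1c(C)cccc1C`, gives 38 nM in this assay. Compound 3, `Cc1cccc(C)c1S(=O)(=O)N1CCC[C@H]1[C@@H](O)CN1CCC[C@@]2(CCN(c3ncnc(N)c3C3CC3)C2)C1`, gives 9 nM in this assay. Compound 3 sits at the low end of these numbers; its gap to compound 1 lies within the usual scatter, so the two cannot be told apart, while compound 2 stands beyond the scatter from compound 3.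

The step now goes from compound 3 to compound 4, `Cc1cccc(C)c1S(=O)(=O)N1CCC[C@@H]1[C@@H](O)CN1CCC[C@@]2(CCN(c3ncnc(N)c3C3CC3)C2)C1`. The change is small on paper: the two compounds have the same atoms and bonds and differ only in configuration as drawn: 1 of 3 stereo elements differ; a stereocentre at a saturated ring carbon is drawn S in compound 3 and R in compound 4. Nothing is added and nothing is removed; only the drawn configuration at one ring carbon is inverted.

Going by the values given here, no measured pair here shows what such an inversion does, so the expectation rests on the general experience that flipping a single stereocentre in an otherwise identical molecule often changes potency, usually toward a weaker inhibitor. The step from compound 3 to compound 4 is therefore expected to be a 3.3-fold higher number from compound 3 to compound 4 (0.52 log units; beyond the scatter), with wide uncertainty in both directions. Compound 4 is estimated to give about 30 nM in this assay, somewhere between 7 nM and 150 nM.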

Compound 4, half-maximal inhibitory concentration: 19 nM
Compound 4: middle estimate off by 1.6-fold (0.20 log units), on the high side, within the range that was stated.
By their numbers in this assay, from the lowest: compounds 3, 1, 4 and 2 (each within the scatter of the next, the first and the last beyond it).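

Going by these compounds alone, this is the first measured pair that differs in one place, and it gives a direct reading of the configuration at this saturated ring carbon. In this assay, inverting it from S to R gives a 2.1-fold higher number from compound 3 to compound 4 (0.32 log units; beyond the scatter), a modest step beyond the scatter, and compound 4 still inhibits at 19 nM. The step can be assigned to this single centre alone because nothing else changes: the fact that compounds 3 and 4 differ only in the configuration as drawn

The compounds shown leave open what inverting either of the other two stereo elements would do, and whether this inversion would have a similar effect on a different core. They also do not show how a fluorine atom or a methyl group on this ring carbon, in place of its hydrogen, would affect inhibition in either configuration.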